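Sulfamoyl in Place of an Ester on the Biaryl

The source may hold more compounds than are shown below. What is called first, only, known or untested is meant among the compounds shown, and "the series" means these compounds.

Compound 1 `CC(C)(N)CC(=O)N[C@@H]1CCc2ccccc2N(Cc2ccc(-c3ccccc3-c3nnn(Cc4ccccc4)n3)cc2)C1=O` gives 1 uM in a functional assay (Pituitary gland cell) with Rattus norvegicus as the target; a lower number here means that less compound is needed, a higher number that more compound is needed for the effect.
Compound 2 `Cn1nnnc1-c1ccccc1-c1ccc(CN2C(=O)[C@H](NC(=O)CC(C)(C)N)CCc3ccccc32)cc1` gives 0.5 uM.
Compound 3 `COC(=O)c1ccccc1-c1ccc(CN2C(=O)[C@H](NC(=O)CC(C)(C)N)CCc3ccccc32)cc1` gives 2 uM.

Compound 3 has the highest number of the three. One step ending there is a 2.0-fold higher number from compound 1 to compound 3 (0.30 log units; within the scatter), the other is a 4.0-fold higher number from compound 2 to compound 3 (0.60 log units; beyond the scatter), so the ester has so far looked, at most, modestly weaker than a tetrazole. Compound 4 `CC(C)(N)CC(=O)N[C@@H]1CCc2ccccc2N(Cc2ccc(-c3ccccc3S(N)(=O)=O)cc2)C1=O` differs from compound 3 in one place: sulfamoyl in place of methoxycarbonyl on an aromatic carbon. Within the data shown here, no measured step involves a sulfamoyl group, so the earlier steps give little guidance beyond showing that changes at this position have stayed small. The expectation is a change within the scatter, a 1.3-fold lower number from compound 3 to compound 4 (0.12 log units; within the scatter). Compound 4 is therefore estimated at 1.5 uM, with a range from 0.5 uM to 5 uM in this assay.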

Compound 4, concentration for half-maximal effect: 3 uM
Compound 4: the middle estimate sits 2.0-fold (0.30 log units) below what was measured; the range from low to high includes it.
By their numbers in this assay, from the lowest: compounds 2, 1, 3 and 4 (each within the scatter of the next, the first and the last beyond it).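

At this aromatic carbon, sulfamoyl and methoxycarbonyl cannot be told apart, with a 1.5-fold higher number from compound 3 to compound 4 (0.18 log units; within the scatter) in this assay even though sulfamoyl carries a hydrogen-bond donor that the ester lacks. Both tetrazole compounds, by contrast, stand clearly apart from the sulfamoyl compound, with a 6.0-fold higher number from compound 2 to compound 4 (0.78 log units; beyond the scatter) and a 3.0-fold higher number from compound 1 to compound 4 (0.48 log units; beyond the scatter) in the same assay, so a new group with a donor did not close the gap to the tetrazoles. From the compounds shown here alone, whether a carboxylic acid or an amine at this carbon would match the tetrazoles remains open. Nothing available here explains these differences.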